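The source may report more compounds than this note shows. Statements on the series, on what has been measured and on what is new or still open speak of the compounds shown alone.

Of the compounds shown here, three sharing one core have been measured in a functional assay on PC-3 cells (Homo sapiens) for antiproliferative activity, read by MTT assay, with a stated time of 48 h; on this read-out lower numbers stand for stronger inhibition and higher numbers for weaker inhibition. Compound 1 `COc1cc(/C=C/C(C)=O)ccc1OCc1cn(-c2ccccc2CO)nn1` gives 50300 nM there. Compound 2 `COc1ccc(-n2cc(COc3ccc(/C=C/C(C)=O)cc3OC)nn2)cc1` differs from compound 1 only at the aromatic nitrogen; in this assay compound 2 gives 2010 nM, and the change 4-methoxyphenyl in place of 2-(hydroxymethyl)phenyl on an aromatic nitrogen produced a 25-fold lower number from compound 1 to compound 2 (1.40 log units; beyond the scatter). Compound 3 `COc1cc(/C=C/C(C)=O)ccc1OCc1cn(-c2ccc(NC(=O)c3ccccc3)cc2)nn1` carries benzamido in place of methoxy on an aromatic carbon and gives 76800 nM in this assay, a change that produced a 38-fold higher number from compound 2 to compound 3 (1.58 log units; beyond the scatter). Compound 3 thus stands at the highest of the three numbers; its nearest neighbour is compound 1, within the scatter, while compound 2 lies far lower.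

Compound 4 `COc1cc(/C=C/C(C)=O)ccc1OCc1cn(-c2ccc([N+](=O)[O-])cc2)nn1` has not yet been measured. Relative to compound 3 the change is nitro in place of benzamido on an aromatic carbon. Going by the values given here, the step that bears directly on this position is the one from compound 2 to compound 3, which was large and upward when benzamido entered; the step from compound 1 to compound 2 concerns a different position and bears only indirectly. Among the compounds with values here, since the benzamido now leaves and a small group enters in its place, a sizeable step downward is expected, a 9.6-fold lower number from compound 3 to compound 4 (0.98 log units; beyond the scatter), though the nitro group itself has no precedent among the measured compounds. Compound 4 is therefore expected to give about 8000 nM in this assay, within a range from 1500 nM to 40000 nM.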

Compound 4, half-maximal inhibitory concentration: 46700 nM
The estimate for compound 4 lay 5.8-fold (0.77 log units) below the measured number; the whole stated range lies below it.
By their numbers in this assay, from the lowest: compound 2; then compounds 4, 1 and 3 (each within the scatter of the next).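

In this assay, nitro in place of benzamido moves the number only slightly, a 1.6-fold lower number from compound 3 to compound 4 (0.22 log units; within the scatter), so the large rise seen when benzamido replaced methoxy cannot be read as belonging to benzamido or to its size: nitro, with far fewer heavy atoms, also lies high, and nitro in place of methoxy gives a 23-fold higher number from compound 2 to compound 4 (1.37 log units; beyond the scatter). Compound 4 also sits level with compound 1, which has 2-(hydroxymethyl)phenyl on the aromatic nitrogen instead of 4-nitrophenyl, a 1.1-fold lower number from compound 1 to compound 4 (0.03 log units; within the scatter), so among these four compounds only compound 2, with its 4-methoxyphenyl group, stands apart, while three quite different aryl groups cannot be told from one another. Nothing available explains why methoxy differs from the other groups.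

The compounds shown leave open whether the lower number is particular to methoxy or would also be seen with another small group on that aromatic carbon, such as an amine, a hydroxyl or a methyl. They also leave open whether a longer chain, such as ethoxy, would keep it.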